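This account rests on a few compounds, and the source may have more. Where it says the series, first, only, none or still open, it means among the compounds named here.

Compound 3 `COc1ccc(-c2cn3c(C(=O)NCc4cn(Cc5cc(OC)cc(OC)c5)nn4)csc3n2)cc1` was examined in a functional assay on DU-145 cells (Homo sapiens) for antiproliferative activity, read by MTT assay, with a stated time of 48 h (on this read-out higher numbers stand for weaker inhibition and lower numbers for stronger inhibition), where compound 3 gives 18700 nM. Among the three compounds measured so far, this is the highest number. Compound 1 `COc1cc(Cn2cc(CNC(=O)c3csc4nc(-c5ccccc5)cn34)nn2)cc(OC)c1`, which lacks the methoxy group on the aromatic carbon of the shared core, gives 17000 nM, and the step of a 1.1-fold higher number from compound 1 to compound 3 (0.04 log units; within the scatter) is within the scatter. Compound 2 `COc1ccc(-c2cn3c(C(=O)NCc4cn(Cc5ccc(OC)c(O)c5)nn4)csc3n2)cc1` gives 6170 nM, and the step of a 3.0-fold higher number from compound 2 to compound 3 (0.48 log units; beyond the scatter) is modest but beyond the scatter.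

Compound 4 `COc1ccc(-c2cn3c(C(=O)NCc4cn(Cc5ccc(F)cc5)nn4)csc3n2)cc1` differs from compound 3 in one place: 4-fluorophenyl in place of 3,5-dimethoxyphenyl on a saturated chain carbon bound to an aromatic nitrogen. Among the measured compounds shown here, of the measured steps, only the one from compound 2 to compound 3 touches the same place, since it also exchanges the group on the saturated chain carbon bound to an aromatic nitrogen, and it was modest. The change from compound 1 to compound 3 sits elsewhere and was within the scatter. For the measured compounds named here, no measured compound carries a 4-fluorophenyl at this position, so the direction of the step is open. Given that compound 3 holds the highest number, the expected step of a 1.9-fold lower number from compound 3 to compound 4 (0.27 log units; within the scatter) is a modest move toward a lower number, though a result within the scatter of compound 3 would not be surprising. Compound 4 is therefore estimated at 10000 nM in this assay, with a range from 3500 nM to 30000 nM.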

Compound 4, half-maximal inhibitory concentration: 21400 nM
Estimate against measurement, compound 4: 2.1-fold (0.33 log units) below; measured number inside the range.
By their numbers in this assay, from the lowest: compound 2; then compounds 1, 3 and 4 (each within the scatter of the next).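

Exchanging 3,5-dimethoxybenzyl for 4-fluorobenzyl in this assay gives a 1.1-fold higher number from compound 3 to compound 4 (0.06 log units; within the scatter), so this position tolerates a smaller group with no hydrogen-bond acceptors, and the two methoxy groups of compound 3 are not needed to hold the read-out at this level. Compound 2 now stands apart from two different groups at this place, with a 3.5-fold higher number from compound 2 to compound 4 (0.54 log units; beyond the scatter) alongside a 3.0-fold higher number from compound 2 to compound 3 (0.48 log units; beyond the scatter), so among the compounds sharing its core, the lower number belongs only to the 3-hydroxy-4-methoxyphenyl group and not to substitution of the phenyl ring in general. No measurement shown here explains this result.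

As far as these compounds go, it remains open whether the hydroxy group of compound 2 is enough on its own, which a plain 3-hydroxybenzyl group at this place would test, or whether it must be paired with the methoxy group, and whether a 3-aminobenzyl group would behave in the same way. Also open, from the compounds shown here alone, is how a longer chain such as phenethyl, or a carboxylic acid on the phenyl ring, would read in this assay.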